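The compounds below may be only part of what the source reports. "The series", "measured", "known", "first", "only" and "open" are said of these compounds alone.

Measured so far: compound 1 `Cc1occc1-c1nnc2sc(Cc3c[nH]c4ccccc34)nn12` with 16%; compound 2 `COc1ccc(Cl)c(-c2nnc3n2NC(c2ccc([N+](=O)[O-])o2)S3)c1` with 15.6%.

In a functional assay on the whole organism (strain Wistar Albino) for inhibition, with Rattus norvegicus as the target, read by paw edema, with a stated time of 1 h, at a dose of 20 mg/kg (on this read-out higher numbers stand for more inhibition at the one dose given (going by the name of the read-out) and lower numbers for less inhibition), compound 1 gives 16% and compound 2 gives 15.6%. The two values lie within the scatter of each other, so neither compound is set apart from the other on the numbers at hand. Compound 3 `COc1ccc(Cl)c(-c2nnc3n2NC(c2cccn2C)S3)c1` is not yet measured and differs from compound 2 in one place: 1-methyl-1H-pyrrol-2-yl in place of 5-nitrofuran-2-yl on a saturated ring carbon. Within the data shown here, no step between measured compounds covers a change of this kind. Since compound 2 stands at 15.6%, a step to compound 3 in this assay beyond the scatter is not expected in either direction. For compound 3 the estimate is 15%, with a range from 5% to 28%. The expected step is a number 0.6 percentage points lower from compound 2 to compound 3 (within the scatter).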

Compound 3, a percentage reported as inhibition, in the whole organism at one dose (the size of the read-out at that dose, not a potency): 14.1%
Estimate against measurement, compound 3: 0.9 percentage points above, and the stated range covers the measured number.
By their numbers in this assay, from the lowest: compounds 3, 2 and 1 (each within the scatter of the next).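

Among these compounds, the first single-place step shows that 1-methyl-1H-pyrrol-2-yl in place of 5-nitrofuran-2-yl on the saturated ring carbon amounts to a number 1.5 percentage points lower from compound 2 to compound 3 (within the scatter) in this assay at the one dose given. On this read-out, the two five-membered aromatic rings are therefore not told apart at this position. Nothing at hand bears on why they read alike.

As far as these compounds go, whether a carboxylic acid or an amine on this saturated ring carbon would separate from compound 2 remains open. So does whether a phenyl ring there would do so.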